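This account rests on a few compounds, and the source may have more. Where it says the series, first, only, none or still open, it means among the compounds named here.

Measured compounds:
compound 1, `COc1cc(C(F)(F)F)cc(C(F)(F)F)c1C(=O)NC1(c2ccccc2)CCCN(C(=O)c2ccccc2)C1`: in an assay on cells for inhibition of sodium- and chloride-dependent glycine transporter 1 (Homo sapiens) (a lower number here means that less compound is needed, a higher number that more compound is needed for the effect), compound 1 gives only a limit, > 10000 nM.
compound 2, `COc1cc(C(F)(F)F)cc(SC)c1C(=O)NC1(c2ccc(C)cc2)CCCN(C)C1`: in this assay compound 2 gives 230 nM.

Within the data shown here, compound 2 thus holds the only real number in this set; the other entry is a limit, (the limit of > 10000 nM in this assay, at which 1 of the 2 values shown sits), and nothing further can be said of compound 1 from it. Compound 3, `COc1cc(C(F)(F)F)cc(SC)c1C(=O)NC1(c2ncccn2)CCCN(C)C1`, is not yet measured. It differs from compound 2 in one place: pyrimidin-2-yl in place of 4-methylphenyl on a saturated ring carbon. Among the measured compounds shown here, no measured pair in this set shows a change of the same kind, so the size of the step rests on expectation alone. A modest loss is expected, beyond the usual scatter but not large, so the step from compound 2 to compound 3 is estimated as a 3.0-fold higher number from compound 2 to compound 3 (0.48 log units; beyond the scatter). Compound 3 is therefore expected to give about 700 nM in this assay, with a likely range from 200 nM to 3000 nM.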

Compound 3, half-maximal effective concentration: > 10000 nM
Compound 3 was reported as a limit; the forecaster's own chance of this, stated with the estimate: 10%; at least 14-fold (1.15 log units) between middle value and limit.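

Among these compounds, exchanging 4-methylphenyl for pyrimidin-2-yl on the saturated ring carbon gives an at least 43-fold higher number from compound 2 to compound 3 (1.63 log units; beyond the scatter) in this assay, the first change at a single place that can be read in this set. A six-membered aromatic ring stands on both sides of this step, so having such a ring at this carbon does not by itself keep the effect. The result for compound 3 is a limit and not a number, and it is the second such entry: the limit of > 10000 nM in this assay, at which 2 of the 3 values shown sit.

The compounds shown do not separate the loss of the methyl group from the entry of the two ring nitrogens. Pyridin-2-yl or 4-chlorophenyl on the same carbon would bear on that question, and how a single ring nitrogen compares with two remains open.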